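A few compounds are considered here, and "the series" means these few. Any claim that something is new, unique, unknown or untested is made for them only; others in the source may bear on it.

Working notes on the series in a functional assay, with a stated time of 2 h, tested at 100 uM; on this read-out lower numbers stand for less inhibition and higher numbers for more inhibition at the one concentration tested (going by the name of the read-out). Compound 1 `CCN(Cc1ccc(F)cc1)Cc1nn(-c2ccccc2F)c2c1CCS(=O)(=O)O2` gives 0.6%. Compound 2 `CCN(Cc1ccccc1)Cc1nn(-c2ccccc2F)c2c1CCS(=O)(=O)O2` gives 1.8%, and compound 3 `CN(Cc1ccc(Cl)cc1)Cc1nn(-c2ccccc2F)c2c1CCS(=O)(=O)O2` gives 6.1%. Among these three numbers compound 1 sits nearest compound 2 and furthest from compound 3, and both gaps stay within the scatter of this assay, so no compound stands apart. For the measured compounds named here, the one measured single-site step, a number 1.2 percentage points higher from compound 1 to compound 2 (within the scatter), shows that hydrogen in place of fluoro on an aromatic carbon leaves the read-out unchanged within the scatter. The step now followed runs from compound 1 to compound 4 `CN(Cc1ccc(F)cc1)Cc1nn(-c2ccccc2F)c2c1CCS(=O)(=O)O2`: hydrogen in place of methyl on a saturated chain carbon bound to an amine nitrogen. Going by the values given here, no measured step alters this chain alone; compound 3 also carries methyl in place of ethyl but differs elsewhere as well, so its value only shows that such a compound sits in the same low range as compound 1. Among the compounds with values here, with the flat a number 1.2 percentage points higher from compound 1 to compound 2 (within the scatter) and the low values of compound 1 and compound 3 as the only guide, compound 4 is expected to show a number 2.4 percentage points higher from compound 1 to compound 4 (within the scatter), within the scatter. Compound 4 is thus estimated at 3%, range -3% to 12%.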

Compound 4, a percentage reported as inhibition, at one concentration (the size of the read-out at that concentration, not a potency): 5.7%
Beside the measured number, compound 4's estimate is 2.7 percentage points below it; low and high end bracket the measured number.
By their numbers in this assay, from the lowest: compounds 1, 2, 4 and 3 (each within the scatter of the next).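

In this assay, for the compounds shown here, the change from ethyl to methyl, read alone for the first time, gives a number 5.1 percentage points higher from compound 1 to compound 4 (within the scatter) and so leaves this saturated chain place without a measurable effect on the read-out. The second new step gives a number 0.4 percentage points lower from compound 3 to compound 4 (within the scatter) and shows that, with methyl on the chain, fluoro in place of chloro on an aromatic carbon also stays within the scatter. Both chain lengths and both halogens therefore remain in the same low range in this assay for these compounds.

From the compounds shown here alone, whether a longer chain such as propyl, or a carboxylic acid in this chain place, would lift the read-out clear of the scatter remains open. No supporting data bear on why these steps stay so small.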